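The source may hold more compounds than are shown below. What is called first, only, known or untested is meant among the compounds shown, and "the series" means these compounds.

In a functional assay with Homo sapiens as the target (on this read-out lower numbers stand for stronger inhibition and higher numbers for weaker inhibition), compound 1 `CC(C)[C@H](NC(=O)COc1cccc2ccccc12)C(=O)N[C@@H](CC(=O)O)C(=O)COC(=O)c1c(Cl)cccc1Cl` gives 11500 nM as its reading, compound 2 `CC(C)[C@H](NC(=O)COc1cccc2ccccc12)C(=O)N[C@@H](CC(=O)O)C(=O)COc1ccccc1C(F)(F)F` gives 17300 nM and compound 3 `CC(C)[C@H](NC(=O)COc1cccc2ccccc12)C(=O)N[C@@H](CC(=O)O)C(=O)COc1cccc(C(F)(F)F)c1` gives 16600 nM on the same scale. Compound 3 thus stands level with the other two, all within the scatter. Compound 4 `CC(C)[C@H](NC(=O)COc1cccc2ccccc12)C(=O)N[C@@H](CC(=O)O)C(=O)COc1ccccc1F` carries 2-fluorophenyl in place of 3-(trifluoromethyl)phenyl on an oxygen on a saturated carbon. Changes at that same place gave only a 1.5-fold higher number from compound 1 to compound 2 (0.18 log units; within the scatter) and a 1.4-fold higher number from compound 1 to compound 3 (0.16 log units; within the scatter) and a 1.0-fold lower number from compound 2 to compound 3 (0.02 log units; within the scatter) in these data. Within the data shown here, no measured compound yet carries 2-fluorophenyl, but with every step so far within the scatter, none beyond it is expected in this assay here. The expected step is a 1.1-fold lower number from compound 3 to compound 4 (0.04 log units; within the scatter) by this estimate. For compound 4 the estimate is 15000 nM with a range from 8000 nM to 28000 nM on this read-out.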

Compound 4, half-maximal inhibitory concentration: 15700 nM
For compound 4 the middle estimate is 1.0-fold (0.02 log units) below the measured one; the measured number falls inside the stated range.
By their numbers in this assay, from the lowest: compounds 1, 4, 3 and 2 (each within the scatter of the next).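

Trading 3-(trifluoromethyl)phenyl, with 10 heavy atoms, for 2-fluorophenyl, with 7, leaves the reading in this assay unchanged within the scatter (a 1.1-fold lower number from compound 3 to compound 4 (0.02 log units; within the scatter)). Fluoro in place of trifluoromethyl on the aromatic carbon also makes no difference beyond the scatter (a 1.1-fold lower number from compound 2 to compound 4 (0.04 log units; within the scatter)), and neither does 2-fluorophenyl in place of (2,6-dichlorophenyl)carbonyl (a 1.4-fold higher number from compound 1 to compound 4 (0.14 log units; within the scatter)). All four groups on this oxygen therefore read alike, including one carrying a single fluoro. Whether an amine on the phenyl ring would shift the reading stays open, and nothing available explains why these groups read alike.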